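Replacing the Benzothiazole by a Nitrobenzimidazole

A few compounds are considered here, and "the series" means these few. Any claim that something is new, unique, unknown or untested is made for them only; others in the source may bear on it.

Compound 1 `CCCCCCN(CCCCCSc1nc2ccccc2o1)C(=O)Nc1ccc(F)cc1F` gives 51000 nM in an assay on microsomes from liver for inhibition of sterol O-acyltransferase 1 (Rattus norvegicus); on this read-out lower numbers stand for stronger inhibition and higher numbers for weaker inhibition.
Compound 2 `CCCCCCN(CCCCCSc1nc2ccccc2s1)C(=O)Nc1ccc(F)cc1F` gives 4000 nM in this assay.
Compound 3 `CCCCCCN(CCCCCSc1nc2cc(C)ccc2[nH]1)C(=O)Nc1ccc(F)cc1F` gives 1000 nM in this assay.

Compound 2 stands second highest of these three numbers: compound 3 is nearest, as the step of a 4.0-fold lower number from compound 2 to compound 3 (0.60 log units; beyond the scatter) shows, and compound 1 is furthest, as the step of a 13-fold lower number from compound 1 to compound 2 (1.11 log units; beyond the scatter) shows. Compound 4 `CCCCCCN(CCCCCSc1nc2cc([N+](=O)[O-])ccc2[nH]1)C(=O)Nc1ccc(F)cc1F` differs from compound 2 in one place: 5-nitro-1H-benzimidazol-2-yl in place of 1,3-benzothiazol-2-yl on a sulfur. The step that bears on this change is a 4.0-fold lower number from compound 2 to compound 3 (0.60 log units; beyond the scatter), where a benzimidazole also replaced the benzothiazole; the step of a 51-fold lower number from compound 1 to compound 3 (1.71 log units; beyond the scatter) points the same way. A lower number is therefore expected in this assay, about a 2.7-fold lower number from compound 2 to compound 4 (0.43 log units; beyond the scatter). Compound 4 is estimated at 1500 nM, within a range from 400 nM to 6000 nM.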

Compound 4, half-maximal inhibitory concentration: 2000 nM
Beside the measured number, compound 4's estimate is 1.3-fold (0.12 log units) below it; measured number inside the range.
By their numbers in this assay, from the lowest: compounds 3, 4 and 2 (each within the scatter of the next, the first and the last beyond it); then compound 1.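

In this assay, 5-nitro-1H-benzimidazol-2-yl on the sulfur cannot be told apart from 1,3-benzothiazol-2-yl (a 2.0-fold lower number from compound 2 to compound 4 (0.30 log units; within the scatter)), and nitro cannot be told apart from methyl on the aromatic carbon (a 2.0-fold higher number from compound 3 to compound 4 (0.30 log units; within the scatter)). The large separation from the 1,3-benzoxazol-2-yl compound persists with nitro in place (a 26-fold lower number from compound 1 to compound 4 (1.41 log units; beyond the scatter)). No measurement on hand accounts for these numbers. Going by these compounds, whether an amine or a carboxylic acid on that aromatic carbon would read differently from nitro and methyl remains open.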